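Cytotoxicity notes on a nitroisoxazole amide series

A few compounds are considered here, and "the series" means these few. Any claim that something is new, unique, unknown or untested is made for them only; others in the source may bear on it.

Measured compounds:
- compound 1 `COc1ccc(CNC(=O)c2c([N+](=O)[O-])noc2-c2ccc(Cl)cc2)cc1`: 89500 nM
- compound 2 `O=C(NCc1cccc(Br)c1)c1c([N+](=O)[O-])noc1-c1ccc(Cl)cc1`: "not determined" (no result reported)
- compound 3 `CCCNC(=O)c1c([N+](=O)[O-])noc1-c1ccc(Cl)cc1`: "not determined" (no result reported)

In an ADME assay on J774.A1 cells (Mus musculus) for cytotoxicity, read by MTT assay, with a stated time of 48 h (on this read-out higher numbers stand for lower toxicity in this test and lower numbers for higher toxicity in this test), compound 1 gives 89500 nM. For compound 2 this assay returned "not determined" (no result reported). For compound 3 this assay returned "not determined" (no result reported). The series thus holds a single measured value. Compound 2 therefore stands without a position on the numbers shown: it cannot be placed above or below compound 1, and no step between measured compounds can be stated.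

Compound 4 `O=C(NCc1cccc(Br)c1)c1c([N+](=O)[O-])noc1-c1ccc(Cl)cc1Cl` differs from compound 2 in one place: chloro in place of hydrogen on an aromatic carbon. Going by the values given here, no measured pair shows what this change does in this assay, so the size of the step is open; the expectation is a step of no more than the usual scatter, in either direction, with the single value of compound 1 as the only anchor for the whole series.

Compound 4 is expected to give about 60000 nM in this assay, with a range from 15000 nM to 200000 nM.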

Compound 4, half-maximal cytotoxic concentration: 71200 nM
Compound 4: middle estimate off by 1.2-fold (0.07 log units), on the low side, and the stated range covers the measured number.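

In this assay compound 4 gives 71200 nM, but compound 2 has no single number, so no step can be read between them. The compounds shown leave open what going from 4-chlorophenyl to 2,4-dichlorophenyl does in this read-out. No supporting evidence bears on this result.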